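This account rests on a few compounds, and the source may have more. Where it says the series, first, only, none or still open, it means among the compounds named here.

Working notes on the series. In an ADME assay on THP-1 cells (Homo sapiens) for cytotoxicity, read by flow cytometry, with a stated time of 72 h (a higher number here means a weaker inhibitor, a lower number a stronger inhibitor), compound 3, `N/C(=N\O)c1ccc(C2=C(S(=O)(=O)c3ccccc3)CC(c3ccccc3)(c3ccccc3)O2)cc1`, gives 30600 nM, the only one of the three results that is a number rather than a limit. Compound 1, `N/C(=N\O)c1ccc(C(=O)CS(=O)(=O)c2ccccc2)cc1`, gives in this assay only a limit of the assay, > 125000 nM. Compound 2, `N/C(=N\O)c1ccc(S(=O)(=O)CC(=O)c2ccccc2)cc1`, likewise gives in this assay only a limit, > 125000 nM. For the measured compounds named here, the series is thus marked by the limit of > 125000 nM in this assay, at which 2 of the 3 values shown sit, and no step between measured compounds can be taken from it. Compound 4 is `N/C(=N\O)c1ccc(C2=C(S(=O)(=O)c3ccc(/C(N)=N/O)cc3)CC(c3ccccc3)(c3ccccc3)O2)cc1`. It differs from compound 3 by a group of 4 heavy atoms (1 carbon, 2 nitrogen, 1 oxygen; no ring) in place of a hydrogen atom, on an aromatic carbon. Nothing measured in the series bears directly on this change. The step expected in this assay is a 1.3-fold higher number from compound 3 to compound 4 (0.12 log units; within the scatter), taken as none beyond the usual scatter, with some chance of a weaker value or of a limit only. Compound 4 is estimated in this assay at 40000 nM, with an expected range from 15000 nM to 125000 nM.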

Compound 4, half-maximal inhibitory concentration: 119000 nM
Beside the measured number, compound 4's estimate is 3.0-fold (0.47 log units) below it; the range from low to high includes it.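

In this assay, for the compounds shown here, a group of 4 heavy atoms in place of a hydrogen atom, on an aromatic carbon para to a large group, gives a 3.9-fold higher number from compound 3 to compound 4 (0.59 log units; beyond the scatter), the first step that can be read as a number. This position therefore does respond to substitution, and here the change moves towards a weaker inhibitor, although this rests on one pair of compounds. Compound 4 still gives a number, but little room remains for reading further steps upward: the limit of > 125000 nM in this assay, at which 2 of the 4 values shown sit.

The compounds shown leave open whether this step is particular to this group or would also follow from a smaller one, such as an amine or a fluorine atom on the same carbon. A carboxylic acid at this position would also test how far the step depends on the group that enters.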